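A few compounds are considered here, and "the series" means these few. Any claim that something is new, unique, unknown or untested is made for them only; others in the source may bear on it.

Of the compounds shown here, two on the shared core have numbers so far in a functional assay on A2780 cells (Homo sapiens) for antiproliferative activity, read by fluorescence, with a stated time of 72 h; on this read-out higher numbers stand for weaker inhibition and lower numbers for stronger inhibition. Compound 1 `CN1CCC(C(=O)N2Cc3c(NC(=O)C4CC4)n[nH]c3C2(C)C)CC1` gives 1420 nM, and compound 2 `CC(C)(C)C(=O)N1Cc2c(NC(=O)C3CCNCC3)n[nH]c2C1(C)C` gives 650 nM. Compound 2 thus holds the lower of the two numbers, and its gap to compound 1 lies beyond the usual scatter. Within the data shown here, these two compounds differ in more than one place, so the gap cannot be assigned to any single change, and no measured step isolates one.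

Compound 3 `CC(C)(C)C(=O)N1Cc2c(NC(=O)c3cccnc3)n[nH]c2C1(C)C` keeps all of compound 2 except one group: pyridin-3-yl in place of piperidin-4-yl on a carbonyl carbon. In words, pyridin-3-yl stands in place of piperidin-4-yl on a carbonyl carbon. Among the measured compounds shown here, with no measured single-place step to draw on, only a small change is expected in this assay, leaning towards a lower number and lying around the edge of the scatter, and that direction is held loosely. The expected size is a 1.7-fold lower number from compound 2 to compound 3 (0.23 log units; within the scatter). For compound 3 the estimated value is 380 nM, with an expected range of 110 nM to 1300 nM.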

Compound 3, half-maximal inhibitory concentration: 690 nM
For compound 3 the middle estimate is 1.8-fold (0.26 log units) below the measured one; measured number inside the range.
By their numbers in this assay, from the lowest: compounds 2 and 3 (each within the scatter of the next); then compound 1.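

In this assay, among these compounds, the first step that changes one place only, pyridin-3-yl in place of piperidin-4-yl on a carbonyl carbon, gives a 1.1-fold higher number from compound 2 to compound 3 (0.03 log units; within the scatter), so the two groups cannot be told apart on this read-out. The earlier pair could not show this, as its two compounds differ in more than one place. Here a six-membered non-aromatic ring with a hydrogen-bond donor gives way to a six-membered aromatic ring with none, at the same heavy-atom count, and no step beyond the scatter follows; nothing available accounts for this result.

Among the compounds shown here, open is whether this place stays as flat for groups of another kind, such as a phenyl ring with no ring nitrogen, an open-chain amine or a carboxylic acid, since only two groups on this carbonyl carbon can be compared so far. Compound 1 differs from compound 2 and from compound 3 in more than one place, so it cannot show whether the step carries over when the rest of the molecule changes.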